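Replacing an ethoxy with a cyclic amine on the pyrazole

The source may hold more compounds than are shown below. What is called first, only, known or untested is meant among the compounds shown, and "the series" means these compounds.

Of the compounds shown here, three sharing one core have been tested in an ADME assay on CHO cells (Cricetulus griseus) for cytotoxicity, read by MTT assay; a lower number here means a stronger inhibitor, a higher number a weaker inhibitor. Compound 1 `Cc1cc(C)n(-c2nc(C(F)(F)F)cc(=O)[nH]2)n1` gives 150000 nM. Compound 2 `CCc1cc(C)nn1-c1nc(C(F)(F)F)cc(=O)[nH]1` gives 108000 nM. The change between them, a 1.4-fold lower number from compound 1 to compound 2 (0.14 log units; within the scatter), is therefore too small to tell the two apart. Compound 3 `CCOc1cc(C)nn1-c1nc(C(F)(F)F)cc(=O)[nH]1` stands differently: in this assay compound 3 gives > 50000 nM, which is a limit of the assay rather than a number. That is the situation described by the limit of > 50000 nM in this assay, at which 1 of the 3 values shown sits, so only a floor for compound 3 is known, not where it actually sits.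

Compound 4 `Cc1cc(NC2CCOCC2)n(-c2nc(C(F)(F)F)cc(=O)[nH]2)n1` has not yet been measured. It differs from compound 3 in one place: (oxan-4-yl)amino in place of ethoxy on an aromatic carbon. Within the data shown here, no measured step bears directly on this change. Among the measured compounds shown here, the one step that can be read, between compound 1 and compound 2, was within the scatter, and the two steps leading to compound 3 cannot be sized because its value is a limit. All three measured compounds are weak in this assay, and nothing among them points to a move beyond the scatter in either direction. The number for compound 4 is expected to be close to that of compound 3, with the step that the limit leaves unreadable from compound 3 to compound 4 estimated to be small. Compound 4 is thus estimated at 80000 nM, within 30000 nM to 200000 nM, and most likely the assay will again report only a limit.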

Compound 4, half-maximal inhibitory concentration: 18000 nM
Estimate against measurement, compound 4: 4.4-fold (0.65 log units) above; measured number outside the range, below it.
By their numbers in this assay, from the lowest: compound 4; then compounds 2 and 1 (each within the scatter of the next).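

Among these compounds, with (oxan-4-yl)amino on this aromatic carbon, this assay shows for the first time a change that lies beyond the scatter: putting it in place of ethoxy gives an at least 2.7-fold lower number from compound 3 to compound 4 (0.44 log units; beyond the scatter). The same group gives a 6.0-fold lower number from compound 2 to compound 4 (0.78 log units; beyond the scatter) when it replaces ethyl, and an 8.3-fold lower number from compound 1 to compound 4 (0.92 log units; beyond the scatter) when it replaces methyl, whereas the earlier change at this carbon, from methyl to ethyl, stayed within the scatter. Compound 3 is known only as a limit, so the steps leading to it from compound 1 and compound 2 cannot be read, and the full size of its step to compound 4 remains unknown: the limit of > 50000 nM in this assay, at which 1 of the 4 values shown sits.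

The compounds shown do not separate the parts of the new group, so it remains open whether the lower number depends on the linking nitrogen with its hydrogen, on the six-membered ring, or on the oxygen within that ring. A simple ethylamino chain, a cyclohexylamino group and a piperidin-4-ylamino group at this carbon would each test one of these parts.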